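Isopropylcarbamoyl for benzyl: a projected step

The source may hold more compounds than are shown below. What is called first, only, known or untested is meant among the compounds shown, and "the series" means these compounds.

Measured compounds:
compound 1, `CN(C)C(=O)/C=C/c1ccc2noc(-c3ccccc3)c2c1`: > 100000 nM
compound 2, `O=C(O)c1ccc2noc(-c3ccc(Cc4ccccc4)cc3)c2c1`: 1290 nM

In an assay for inhibition of inositol hexakisphosphate kinase 3 (Homo sapiens), read by colorimetric assay, coupled enzyme assay and malachite green, with a stated time of 120 min, in the presence of a further agent that is not named here (on this read-out higher numbers stand for weaker inhibition and lower numbers for stronger inhibition), compound 1 gives > 100000 nM, which is a limit of the assay and not a number (the limit of > 100000 nM in this assay, at which 1 of the 2 values shown sits). In this assay compound 2 gives 1290 nM, the only number shown. Compound 3, `CC(C)NC(=O)c1ccc(-c2onc3ccc(C(=O)O)cc23)cc1`, differs from compound 2 by isopropylcarbamoyl in place of benzyl on an aromatic carbon. For the measured compounds named here, no measured step of this kind exists, so the expected step is uncertain; a loss of moderate size, somewhat beyond the scatter, is expected: a 2.7-fold higher number from compound 2 to compound 3 (0.43 log units; beyond the scatter). Compound 3 is estimated at 3500 nM, within 700 nM to 18000 nM.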

Compound 3, half-maximal inhibitory concentration: 340 nM
For compound 3 the middle estimate is 10-fold (1.01 log units) above the measured one; measured number outside the range, below it.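

The aromatic carbon para to a large group does not depend on the benzyl ring: in this assay, isopropylcarbamoyl in place of benzyl gives a 3.8-fold lower number from compound 2 to compound 3 (0.58 log units; beyond the scatter). A group with no ring, carrying a hydrogen-bond donor and a hydrogen-bond acceptor, is therefore accepted at this place. No measurement at hand accounts for the gain.

Still open, as far as these compounds go, is whether the amide hydrogen, the carbonyl or the isopropyl group carries this step. A dimethylamide, a cyclopropyl amide or a longer chain on the amide nitrogen would help separate these parts.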